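Replacing an Arylthio Group by Bromine on a Nitroimidazopyridine

A few compounds are considered here, and "the series" means these few. Any claim that something is new, unique, unknown or untested is made for them only; others in the source may bear on it.

Measured compounds:
- compound 1, `Cc1nc2c(Sc3ccc(Cl)cc3)cc(Cl)cn2c1[N+](=O)[O-]`: > 7800 nM
- compound 2, `Cc1cc(Sc2ccc(Cl)cc2)c2nc(CS(=O)(=O)c3ccccc3)c([N+](=O)[O-])n2c1`: > 62500 nM

Of the compounds shown here, two have been tested in an ADME assay on HepG2 cells (Homo sapiens) for cytotoxicity, read by MTT assay, with a stated time of 72 h; on this read-out higher numbers stand for lower toxicity in this test and lower numbers for higher toxicity in this test. Compound 1, `Cc1nc2c(Sc3ccc(Cl)cc3)cc(Cl)cn2c1[N+](=O)[O-]`, gives > 7800 nM, which is a limit of this assay and not a number. Compound 2, `Cc1cc(Sc2ccc(Cl)cc2)c2nc(CS(=O)(=O)c3ccccc3)c([N+](=O)[O-])n2c1`, gives > 62500 nM, likewise a limit of this assay rather than a number. Compound 2 therefore stands at the limit of > 62500 nM in this assay, at which 1 of the 2 values shown sits, while compound 1 stands at the limit of > 7800 nM in this assay, at which 1 of the 2 values shown sits; with only limits on both sides, no ordering of the two can be drawn.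

The step to compound 3, `Cc1cc(Br)c2nc(CS(=O)(=O)c3ccccc3)c([N+](=O)[O-])n2c1`, consists of bromo in place of (4-chlorophenyl)sulfanyl on an aromatic carbon. Among the compounds with values here, no measured step of this kind is available. Compound 2 already sits at a limit, so no step beyond the scatter is expected from compound 2 to compound 3, and an at least 1.1-fold lower number from compound 2 to compound 3 (0.05 log units; that floor lies within the scatter) expresses that. Compound 3 is estimated at 55000 nM, within 15000 nM to 62500 nM, most likely reported as a limit again.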

Compound 3, half-maximal cytotoxic concentration: > 31200 nM
Compound 3 was reported as a limit; the forecaster's own chance of this, stated with the estimate: 65%; the middle value is on the limit's open side.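

Compound 2 and compound 3 are both reported only as limits in this assay, so no step can be read for bromo in place of (4-chlorophenyl)sulfanyl. The compounds shown leave open the actual half-maximal cytotoxic concentration of each compound, and whether this replacement changes it.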